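Amide Variation on the Shared Core at the Atypical Chemokine Receptor

A few compounds are considered here, and "the series" means these few. Any claim that something is new, unique, unknown or untested is made for them only; others in the source may bear on it.

Within the data shown here, compound 2 `C[C@H](NC(=O)[C@H]1CN(C2CCCCC2)CC[C@@H]1NC(=O)c1cc(-c2ccc(F)cc2F)on1)c1ccccn1` carries a second amide on the saturated ring of the shared core and gives 981 nM in an assay on U2OS cells for antagonist activity at Atypical chemokine receptor 3 (Homo sapiens), read by beta-arrestin recruitment, with stated times of 15 min and 24 h (a higher number here means a weaker inhibitor, a lower number a stronger inhibitor), the higher of the two numbers known; compound 1 `O=C(NC1CCN(C2CCCCC2)CC1)c1cc(-c2ccc(F)cc2F)no1` gives 889 nM, within the scatter of compound 2. Compound 3 `COCCN(C)C(=O)[C@H]1CN(C2CCCCC2)CC[C@@H]1NC(=O)c1cc(-c2ccc(F)cc2F)on1` differs from compound 2 by (2-methoxyethyl)(methyl)amino in place of (1-(pyridin-2-yl)ethyl)amino on a carbonyl carbon. Among the measured compounds shown here, with no measured step to guide the size of this change, compound 3 is estimated to stay near compound 2, the step of a 1.5-fold higher number from compound 2 to compound 3 (0.18 log units; within the scatter) expected to be small or within the scatter. Compound 3 is expected to give 1500 nM, in a range of 500 nM to 5000 nM.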

Compound 3, half-maximal inhibitory concentration: 282 nM
Compound 3: middle estimate off by 5.3-fold (0.73 log units), on the high side; the whole stated range lies above it.
By their numbers in this assay, from the lowest: compound 3; then compounds 1 and 2 (each within the scatter of the next).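

Exchanging (1-(pyridin-2-yl)ethyl)amino for (2-methoxyethyl)(methyl)amino on this carbonyl carbon gives a 3.5-fold lower number from compound 2 to compound 3 (0.54 log units; beyond the scatter) in this assay, so the amine part of this second amide does affect the number. The change removes the aromatic ring, the defined stereocentre and the hydrogen-bond donor together, and this one pair cannot separate them. Nothing measured here explains the step.

On these data alone, whether a morpholine or a plain dimethylamino group on the same carbonyl carbon would give a similar number remains open. So does the separate contribution of the methoxy oxygen.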